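The source may hold more compounds than are shown below. What is called first, only, known or untested is meant among the compounds shown, and "the series" means these compounds.

Measured in a functional assay on LoVo cells (Homo sapiens) for inhibition, read by MTT assay, with a stated time of 24 h; a lower number here means a stronger inhibitor, a higher number a weaker inhibitor:
- Compound 1 `CC1(C)[C@H]2CC[C@]1(C)N(Cc1cn(-c3cccc(F)c3)nn1)C(=O)C2`: 90 nM
- Compound 2 `CC1(C)[C@H]2CC[C@]1(C)N(Cc1cn(-c3ccc(C#N)cc3)nn1)C(=O)C2`: 90 nM
- Compound 3 `CC1(C)[C@H]2CC[C@]1(C)N(Cc1cn(-c3ccccc3Cl)nn1)C(=O)C2`: 190 nM

Compound 3 has the highest number of the three, at 190 nM, which makes it the weakest inhibitor measured so far. The next compound, compound 4 `Cc1ccc(-n2cc(CN3C(=O)C[C@@H]4CC[C@@]3(C)C4(C)C)nn2)cc1`, keeps the shared core but carries 4-methylphenyl in place of 2-chlorophenyl on an aromatic nitrogen.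

Within the data shown here, three measured steps bear on this change. The 2-chlorophenyl group came with a 2.1-fold higher number from compound 1 to compound 3 (0.32 log units; beyond the scatter) and with a 2.1-fold higher number from compound 2 to compound 3 (0.32 log units; beyond the scatter), both modest. Exchanging the two other aryl groups gave no change at the digits printed from compound 1 to compound 2 (within the scatter), so those two compounds do not differ beyond the scatter. Among the measured compounds shown here, no measured compound carries 4-methylphenyl, so any forecast is uncertain. Leaving 2-chlorophenyl may still recover a similarly modest gain in this assay. The expected change is a 1.7-fold lower number from compound 3 to compound 4 (0.24 log units; within the scatter), a small move toward a lower number. For compound 4 the estimated value is 110 nM, with an expected range of 50 nM to 240 nM.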

Compound 4, half-maximal inhibitory concentration: 50 nM
The estimate for compound 4 lay 2.2-fold (0.34 log units) above the measured number; low and high end bracket the measured number.
By their numbers in this assay, from the lowest: compounds 4, 1 and 2 (each within the scatter of the next); then compound 3.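

In this assay, 4-methylphenyl in place of 2-chlorophenyl on the aromatic nitrogen gave a 3.8-fold lower number from compound 3 to compound 4 (0.58 log units; beyond the scatter), which leaves compound 3 as the weakest of the four and shows that this position accepts a methyl-bearing aryl group. Compound 4 does not separate from the other two: methyl in place of cyano gave a 1.8-fold lower number from compound 2 to compound 4 (0.26 log units; within the scatter), and 4-methylphenyl in place of 3-fluorophenyl gave a 1.8-fold lower number from compound 1 to compound 4 (0.26 log units; within the scatter), so methyl, cyano and fluorine cannot be told apart in these compounds. Nothing measured here explains the gap between compound 3 and the others.

Still open, going by these compounds, is whether the chlorine itself or its place in 2-chlorophenyl sets compound 3 apart, a question that 4-chlorophenyl would address. On these data alone, it is also open how this assay responds to an amine or a carboxylic acid in place of the methyl of 4-methylphenyl.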